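Swapping the methoxyphenyl for a chlorophenyl

A few compounds are considered here, and "the series" means these few. Any claim that something is new, unique, unknown or untested is made for them only; others in the source may bear on it.

Of the compounds shown here, three built on the same core have been tested in a functional assay on MCF7 cells (Homo sapiens) for inhibition, read by MTT assay, with a stated time of 72 h; on this read-out lower numbers stand for stronger inhibition of growth and higher numbers for weaker inhibition of growth. Compound 1 `O=S(=O)(NCCCNCc1ccc(Br)cc1)c1cc(C(F)(F)F)cc(C(F)(F)F)c1` gives 1900 nM. Compound 2 `O=S(=O)(NCCCNCc1ccc(-c2ccccc2)cc1)c1cc(C(F)(F)F)cc(C(F)(F)F)c1` gives 1700 nM. Compound 3 `COc1cccc(CNCCCNS(=O)(=O)c2cc(C(F)(F)F)cc(C(F)(F)F)c2)c1` gives 2400 nM. The three numbers sit close together: compound 3 has the largest of them, yet its gap to compound 1 and to compound 2 is within the scatter.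

Compound 4 `O=S(=O)(NCCCNCc1ccc(Cl)cc1)c1cc(C(F)(F)F)cc(C(F)(F)F)c1` differs from compound 3 in one place: 4-chlorophenyl in place of 3-methoxyphenyl on a saturated chain carbon bound to an amine nitrogen. Going by the values given here, two measured steps bear on this. The step of a 1.3-fold higher number from compound 1 to compound 3 (0.10 log units; within the scatter) swapped a bromine-bearing ring for the methoxy-bearing ring, and the step of a 1.1-fold lower number from compound 1 to compound 2 (0.05 log units; within the scatter) swapped bromine for phenyl; neither moved the number beyond the scatter. The change to compound 4 is close to undoing the first of these, with chlorine in place of bromine.

Compound 4 is therefore expected to give about 1900 nM in this assay, between 1000 nM and 3600 nM, a step of a 1.3-fold lower number from compound 3 to compound 4 (0.10 log units; within the scatter) that is expected to stay within the scatter.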

Compound 4, concentration for 50% growth inhibition: 2400 nM
Beside the measured number, compound 4's estimate is 1.3-fold (0.10 log units) below it, within the range that was stated.
By their numbers in this assay, from the lowest: compounds 2, 1, 3 and 4 (each within the scatter of the next).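

In this assay the step to 4-chlorophenyl in place of 3-methoxyphenyl gives no change at the digits printed from compound 3 to compound 4 (within the scatter) even though the group that leaves counts one hydrogen-bond acceptor and the group that enters counts none, so at this place, on a saturated chain carbon bound to an amine nitrogen, that difference comes with no shift beyond the scatter. The substituent on the ring can also be exchanged in two further ways without leaving the scatter: chloro for bromo gives a 1.3-fold higher number from compound 1 to compound 4 (0.10 log units; within the scatter) and chloro for phenyl gives a 1.4-fold higher number from compound 2 to compound 4 (0.15 log units; within the scatter) in the same read-out. No measurement here explains why these four numbers stay so close.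

What the compounds shown leave open is whether any group on this ring moves the number beyond the scatter. A carboxylic acid or an amine on the ring, or a longer chain in the shared core, could test that.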